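Swapping chloro for trifluoromethoxy in a growth-inhibition test

The compounds below may be only part of what the source reports. "The series", "measured", "known", "first", "only" and "open" are said of these compounds alone.

In a functional assay on KB cells (Homo sapiens) for inhibition, read by MTT assay, with a stated time of 24 h, tested at 10 ug/mL (a higher number here means more inhibition of growth at the concentration tested, a lower number less inhibition of growth), compound 1 (`O=C(CCCCC1CCSS1)NO`) gives 0.89%, compound 2 (`O=C(CCCCC(S)CCS)Nc1ccccc1`) gives 8.62%, and compound 3 (`O=C(CCCCC(S)CCS)Nc1ccc(Cl)cc1`) gives 18.2%. Compound 3 therefore lies within the usual scatter of compound 2 but beyond it from compound 1. Compound 4 (`O=C(CCCCC(S)CCS)Nc1ccc(OC(F)(F)F)cc1`) has trifluoromethoxy in place of chloro on an aromatic carbon. Among the measured compounds shown here, only one measured step bears on this change, with chloro in place of hydrogen on an aromatic carbon: a number 9.6 percentage points higher from compound 2 to compound 3 (within the scatter). For the measured compounds named here, that step stayed within the scatter, and no measured compound yet carries trifluoromethoxy, so no clear shift is expected. The expected change in this assay is a number 1.8 percentage points higher from compound 3 to compound 4 (within the scatter), which is no step beyond the scatter. For compound 4 the estimated value is 20%, with an expected range from 8% to 35%.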

Compound 4, percent growth inhibition at one concentration: 15%
Compound 4: middle estimate off by 5 percentage points, on the high side; low and high end bracket the measured number.
By their numbers in this assay, from the lowest: compounds 1, 2, 4 and 3 (each within the scatter of the next, the first and the last beyond it).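

In this assay trifluoromethoxy in place of chloro on this aromatic carbon gives a number 3.2 percentage points lower from compound 3 to compound 4 (within the scatter) so the two groups cannot be told apart here. Trifluoromethoxy in place of hydrogen gives a number 6.4 percentage points higher from compound 2 to compound 4 (within the scatter) so even this group of 5 heavy atoms brings no step beyond the scatter at this position. No measurement at hand explains these numbers. Still open, as far as these compounds go, is whether an amine or a carboxylic acid on this aromatic carbon would move the number beyond the scatter.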